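The compounds below may be only part of what the source reports. "The series", "measured", "known", "first", "only" and "open" are said of these compounds alone.

Measured compounds:
compound 1 `CCCC(CC)n1ccc2cc(/C(C)=C/C(=O)Nc3ccccc3OCCCC(=O)O)ccc21`: 9.3 nM
compound 2 `C/C(=C\C(=O)Nc1ccccc1OCCCC(=O)O)c1ccc2c(ccn2Cc2ccc(F)cc2)c1`: 97 nM
compound 3 `C/C(=C\C(=O)Nc1ccccc1OCCCC(=O)O)c1ccc2c(ccn2C(C)c2ccccc2)c1`: 19 nM

In an assay on Prostate gland for inhibition of steroid 5-alpha-reductase (Rattus norvegicus) (on this read-out lower numbers stand for stronger inhibition and higher numbers for weaker inhibition), compound 1 gives the lowest number of the three, with compound 3 the nearest and compound 2 the furthest. The two measured steps away from compound 1 both raise the number: a 10-fold higher number from compound 1 to compound 2 (1.02 log units; beyond the scatter) and a 2.0-fold higher number from compound 1 to compound 3 (0.31 log units; beyond the scatter). Between the other two, a 5.1-fold lower number from compound 2 to compound 3 (0.71 log units; beyond the scatter).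

Compound 4 `CCCC(c1ccccc1)n1ccc2cc(/C(C)=C/C(=O)Nc3ccccc3OCCCC(=O)O)ccc21` differs from compound 1 in one place: phenyl in place of ethyl on a saturated chain carbon bound to an aromatic nitrogen and a saturated chain carbon. Among the measured compounds shown here, of the measured steps, the one from compound 1 to compound 3 bears most directly on this change, since there too a phenyl ring arrives on the saturated chain carbon bound to the aromatic nitrogen while the rest of the shared core is untouched; that step was modest. The step to compound 2 also brings an aromatic ring onto the aromatic nitrogen and was large, but it removes the branching at that carbon, which compound 4 keeps. A modest rise in this assay, of roughly the size seen for compound 3, is therefore expected for compound 4, as a 1.7-fold higher number from compound 1 to compound 4 (0.24 log units; within the scatter). Compound 4 is estimated at 16 nM, with a range from 6 nM to 45 nM.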

Compound 4, half-maximal inhibitory concentration: 9.1 nM
Estimate against measurement, compound 4: 1.8-fold (0.25 log units) above; measured number inside the range.
By their numbers in this assay, from the lowest: compounds 4 and 1 (each within the scatter of the next); then compound 3; then compound 2.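

In this assay the exchange of ethyl for phenyl on this saturated chain carbon gives a 1.0-fold lower number from compound 1 to compound 4 (0.01 log units; within the scatter) and leaves the two compounds indistinguishable on this read-out. A phenyl ring on this carbon therefore does not in itself go with a higher number here, which compound 3 could not show, as it differs from compound 1 in the whole 1-phenylethyl group. With the phenyl ring held in place, the length of the chain on that carbon does register: ethyl in place of hydrogen gives a 2.1-fold lower number from compound 3 to compound 4 (0.32 log units; beyond the scatter) and 1-phenylbutyl in place of 4-fluorobenzyl gives an 11-fold lower number from compound 2 to compound 4 (1.03 log units; beyond the scatter) in a step that alters the branching and the ring fluorine together.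

These compounds do not separate the branching from the fluorine in that last step, and they leave open whether a cyclohexyl ring, a hydroxyl or an amine on this saturated chain carbon would match compound 1 and compound 4. Nothing at hand gives a reason for any of these numbers.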